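This account rests on a few compounds, and the source may have more. Where it says the series, first, only, none or still open, it means among the compounds named here.

Compound 1 `COc1ccc(C(=O)c2sc(Nc3ccccc3)nc2N)cc1OC`: 5500 nM
Compound 2 `COc1ccc(Nc2nc(N)c(C(=O)c3ccc(OC)c(OC)c3)s2)cc1`: 37 nM
Compound 3 `COc1ccc(Nc2nc(N)c(C(=O)c3cccc(OC)c3)s2)cc1`: not yet measured

In a functional assay on MOLT-4 cells (Homo sapiens) for antiproliferative activity, read by cell counting, with a stated time of 2 days (a higher number here means a weaker inhibitor, a lower number a stronger inhibitor), compound 2 holds the lower of the two numbers, at 37 nM, and compound 1 is its nearest neighbour. Compound 3 differs from compound 2 by one change: hydrogen in place of methoxy on an aromatic carbon. Among the compounds with values here, only one measured step bears on this, a large one of the reverse kind at a different place in the molecule: a 150-fold lower number from compound 1 to compound 2 (2.17 log units; beyond the scatter), with methoxy in place of hydrogen. As that step lies elsewhere, it is only a loose guide, so a higher number is expected, though by a smaller margin. The expected change is an 11-fold higher number from compound 2 to compound 3 (1.03 log units; beyond the scatter). For compound 3 the estimated value is 400 nM, with an expected range from 70 nM to 3000 nM.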

Compound 3, half-maximal inhibitory concentration: 4 nM
Estimate against measurement, compound 3: 100-fold (2.00 log units) above; measured number below the stated range.
By their numbers in this assay, from the lowest: compound 3; then compound 2; then compound 1.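

In this assay, the step of a 9.3-fold lower number from compound 2 to compound 3 (0.97 log units; beyond the scatter) shows that the methoxy para to a large group and ortho to a methoxy group is not needed for a low number, and that compound 3 does better with hydrogen there. The earlier step, a 150-fold lower number from compound 1 to compound 2 (2.17 log units; beyond the scatter), came with methoxy entering at a different place, so the two steps together show that the effect of a methoxy depends on where it sits on the molecule. Nothing shown here explains why hydrogen gives the lower number at this position.

The compounds shown leave open how a hydroxyl, an amine or a longer chain such as ethoxy would compare with hydrogen and methoxy at this position. They also leave open whether the remaining methoxy on this ring contributes to the low number of compound 3.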